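The compounds below may be only part of what the source reports. "The series", "measured", "known", "first", "only" and "open" are said of these compounds alone.

Compound 1 `O=C1[C@@H](Cc2n[nH]c3ccccc23)C(=O)N(c2ccccc2)C=CN1CC(=O)N1CCCCc2ccccc21` is the reference point of this small set. In a functional assay on CHO cells for agonist activity at Melanocortin receptor 4 (Homo sapiens), read by a luciferase reporter, with a stated time of 4 h (a lower number here means that less compound is needed, a higher number that more compound is needed for the effect), compound 1 gives 100 nM. Compound 3 `COc1ccc(N(C(=O)CN2C=CN(c3ccccc3)C(=O)[C@H](Cc3n[nH]c4ccccc34)C2=O)C(C)C)cc1` differs from it by a group of 12 heavy atoms (10 carbon, 1 nitrogen, 1 oxygen; one six-membered aromatic ring of carbon only) in place of a group of 11 heavy atoms (10 carbon, 1 nitrogen; one six-membered aromatic ring of carbon only, one seven-membered non-aromatic ring with 1 hetero atom), on a carbonyl carbon, and in this assay compound 3 gives 339 nM, so this change made a 3.4-fold higher number from compound 1 to compound 3 (0.53 log units; beyond the scatter).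

Compound 2 `O=C1C(Cc2n[nH]c3cc(F)ccc23)C(=O)N(c2ccccc2)C=CN1CC(=O)N1CCCCc2ccccc21` has a different core; how it differs from the core of compound 1 is not broken down here. In this assay compound 2 gives 437 nM, the highest number among the three measured compounds, beyond the scatter from compound 1 but within the scatter of compound 3.

Compound 4 `COc1ccc(N(C(=O)CN2C=CN(c3ccccc3)C(=O)C(Cc3n[nH]c4cc(F)ccc34)C2=O)C(C)C)cc1` is not yet measured. It differs from compound 2 by a group of 12 heavy atoms (10 carbon, 1 nitrogen, 1 oxygen; one six-membered aromatic ring of carbon only) in place of a group of 11 heavy atoms (10 carbon, 1 nitrogen; one six-membered aromatic ring of carbon only, one seven-membered non-aromatic ring with 1 hetero atom), on a carbonyl carbon, the same change that turned compound 1 into compound 3. Because that change made a 3.4-fold higher number from compound 1 to compound 3 (0.53 log units; beyond the scatter), the expectation is that a step of similar size will follow here as well, which would put compound 4 further still from compound 1. He therefore expects a step of a 3.0-fold higher number from compound 2 to compound 4 (0.47 log units; beyond the scatter) in this assay. For compound 4 the estimate in this assay is 1300 nM, with a likely range from 500 nM to 3500 nM.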

Compound 4, half-maximal effective concentration: 355 nM
Estimate against measurement, compound 4: 3.7-fold (0.56 log units) above; the whole stated range lies above it.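

On the core of compound 2, putting isopropyl(4-methoxyphenyl)amino on the carbonyl carbon in place of the group with the seven-membered ring gave a 1.2-fold lower number from compound 2 to compound 4 (0.09 log units; within the scatter) in this assay, so on this core the exchange stayed within the scatter. Set beside the step on the core of compound 1, the same change did not carry over from one core to the other with the same size: the same change on two cores in this assay, a 3.4-fold higher number (0.53 log units; beyond the scatter) from compound 1 to compound 3 and a 1.2-fold lower number (0.09 log units; within the scatter) from compound 2 to compound 4, 4.2-fold (0.62 log units) apart, beyond the scatter of two such steps This shows that, in this series, a step seen on one core cannot simply be transferred to another, but it rests on only two pairs and does not show which difference between the cores lies behind the gap or how the change would behave on a third core.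

The compounds shown leave open whether a smaller group on the carbonyl carbon, such as diethylamino or morpholine, would also give different steps on the two cores. On these data alone, it also remains open whether a core with chlorine in place of the fluorine of compound 2 would follow the step seen on the core of compound 1 or the one seen on the core of compound 2.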